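Swapping the amide substituent in a glutamate receptor modulator series

The source may hold more compounds than are shown below. What is called first, only, known or untested is meant among the compounds shown, and "the series" means these compounds.

For the measured compounds named here, compound 1 `O=C(O)c1cc(-c2cccc(COc3ccc4c(c3)CN(c3ccccc3)C4=O)c2)ccc1Cl` is one of three compounds measured in an assay on HEK293 cells for positive allosteric modulation of metabotropic glutamate receptor 2 (Rattus norvegicus), read by thallium flux; on this read-out higher numbers stand for an effect only at larger amounts of compound and lower numbers for an effect already at smaller amounts. In this assay compound 1 gives 260 nM, the second highest of the three numbers. Compound 2 `O=C(O)c1cc(-c2cccc(COc3ccc4c(c3)CCN(C3CCCC3)C4=O)c2)ccc1Cl` gives 300 nM in this assay, and compound 3 `Cc1c(OCc2cccc(-c3ccc(Cl)c(C(=O)O)c3)c2)cc2c(c1C)C(=O)C(C1CCCC1)C2` gives 180 nM in this assay. Both of these lie within the usual scatter of the number for compound 1, so the three compounds stand level. Compound 4 `CC(C)CN1Cc2cc(OCc3cccc(-c4ccc(Cl)c(C(=O)O)c4)c3)ccc2C1=O` has not yet been measured. It differs from compound 1 in one place: isobutyl in place of phenyl on an amide-type nitrogen in a ring. The measured compounds already carry different groups on that nitrogen without separating beyond the scatter. The step of a 1.3-fold higher number from compound 1 to compound 4 (0.13 log units; within the scatter) is therefore expected to stay within the scatter, with no clear direction. Compound 4 is expected to give about 350 nM in this assay, between 150 nM and 900 nM.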

Compound 4, half-maximal effective concentration: 100 nM
Estimate against measurement, compound 4: 3.5-fold (0.54 log units) above; measured number outside the range, below it.
By their numbers in this assay, from the lowest: compounds 4, 3, 1 and 2 (each within the scatter of the next, the first and the last beyond it).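

For the compounds shown here, the step of a 2.6-fold lower number from compound 1 to compound 4 (0.41 log units; beyond the scatter) in this assay shows that the substituent on this amide-type nitrogen in a ring can move the number beyond the scatter, which the earlier compounds, differing in more than one place, could not show. An aromatic ring on this nitrogen is thus not needed for the lower number in this pair, since isobutyl has no ring. No measurement shown gives a reason for this step.

As far as these compounds go, whether a shorter chain such as ethyl or a longer chain such as hexyl would lower the number further at this nitrogen remains open. So does the effect of a chain carrying an amine there.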